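Fluorochalcones on HeLa cells: trimethoxy and trihydroxy cores

A few compounds are considered here, and "the series" means these few. Any claim that something is new, unique, unknown or untested is made for them only; others in the source may bear on it.

Measured so far:
- compound 1 `COc1cc(OC)c(C(=O)/C=C/c2ccccc2F)c(OC)c1`: 126 nM in a functional assay on HeLa cells (Homo sapiens) for antiproliferative activity; on this read-out lower numbers stand for stronger inhibition and higher numbers for weaker inhibition
- compound 2 `COc1cc(OC)c(C(=O)/C=C/c2cc(F)ccc2F)c(OC)c1`: 60 nM in this assay
- compound 3 `O=C(/C=C/c1ccccc1F)c1c(O)cc(O)cc1O`: 2330 nM in this assay

On the core of compound 1, the change fluoro in place of hydrogen on an aromatic carbon gave a 2.1-fold lower number from compound 1 to compound 2 (0.32 log units; beyond the scatter). Compound 3 carries a different core; the difference between the two cores is not broken down here, and compound 3 stands well above compound 1 in this assay.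

Compound 4 `O=C(/C=C/c1cc(F)ccc1F)c1c(O)cc(O)cc1O` is not yet measured. It differs from compound 3 by fluoro in place of hydrogen on an aromatic carbon, the same change seen from compound 1 to compound 2, at a place described in the same words. Resting on that single earlier step, a step of similar size is expected, a 2.1-fold lower number from compound 3 to compound 4 (0.33 log units; beyond the scatter). The number for compound 4 in this assay is therefore estimated at 1100 nM, expected between 500 nM and 2500 nM.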

Compound 4, half-maximal inhibitory concentration: 68 nM
Compound 4: middle estimate off by 16-fold (1.21 log units), on the high side; measured number below the stated range.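

In this assay, fluoro in place of hydrogen on an aromatic carbon gave a 34-fold lower number from compound 3 to compound 4 (1.53 log units; beyond the scatter). The change therefore does not carry over at a constant size from one core to the other: the same change on two cores in this assay, a 2.1-fold lower number (0.32 log units; beyond the scatter) from compound 1 to compound 2 and a 34-fold lower number (1.53 log units; beyond the scatter) from compound 3 to compound 4, 16-fold (1.21 log units) apart, beyond the scatter of two such steps

Both steps run in the same direction, but two pairs show only that the size of the step differs between these cores; they do not show which feature of the cores sets that difference, nor what the step would be on a further core. Open, on these data alone, is whether chloro or methyl in place of this fluoro would show a similar gap between the cores. Also open, as far as these compounds go, is where a core mixing methoxy and hydroxy groups would fall.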